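The source may report more compounds than this note shows. Statements on the series, on what has been measured and on what is new or still open speak of the compounds shown alone.

In a functional assay on HepG2 cells (Homo sapiens) for cytotoxicity, read by MTT assay, with a stated time of 24 h (a lower number here means a stronger inhibitor, a higher number a weaker inhibitor), compound 1 `CC(=O)Nc1ccc(S(=O)(=O)N2C/C(=C\c3ccc(C#N)cc3)C(=O)/C(=C/c3ccc(C#N)cc3)C2)cc1` gives 4880 nM, compound 2 `N#Cc1ccc(/C=C2\CN(S(=O)(=O)c3ccc(F)cc3)C/C(=C\c3ccccc3F)C2=O)cc1` gives 8180 nM, and compound 3 `CC(=O)Nc1ccc(S(=O)(=O)N2C/C(=C\c3cccc([N+](=O)[O-])c3)C(=O)/C(=C/c3ccccc3F)C2)cc1` gives 8800 nM. Compound 3 therefore stands within the usual scatter of both other compounds, so these three numbers do not separate into a clear ranking. The next compound to be tested is compound 4 `CC(=O)Nc1ccc(S(=O)(=O)N2C/C(=C\c3ccc(C#N)cc3)C(=O)/C(=C/c3ccccc3F)C2)cc1`. It keeps the rest of compound 3 and makes one structural change: 4-cyanophenyl in place of 3-nitrophenyl on a double-bonded chain carbon bound to a double-bonded ring carbon. Within the data shown here, no measured pair here isolates a change of this kind, so any expectation is tentative. The closest guide is compound 1, which also carries 4-cyanophenyl at this place and gives 4880 nM. In this assay, a small move towards a lower number is therefore expected, but nothing beyond the scatter. The estimated change, a 1.4-fold lower number from compound 3 to compound 4 (0.13 log units; within the scatter), would leave the result close to the existing values. The estimate for compound 4 is 6500 nM, with an expected range from 3500 nM to 12000 nM.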

Compound 4, half-maximal inhibitory concentration: 4960 nM
Beside the measured number, compound 4's estimate is 1.3-fold (0.12 log units) above it, and the stated range covers the measured number.
By their numbers in this assay, from the lowest: compounds 1, 4, 2 and 3 (each within the scatter of the next).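

In this assay, among these compounds, compound 4 provides the first comparisons that change a single place, and all of them stay within the scatter. On a double-bonded chain carbon bound to a double-bonded ring carbon, 4-cyanophenyl in place of 3-nitrophenyl gives (a 1.8-fold lower number from compound 3 to compound 4 (0.25 log units; within the scatter)), and 2-fluorophenyl in place of 4-cyanophenyl gives (a 1.0-fold higher number from compound 1 to compound 4 (0.01 log units; within the scatter)), so the three aromatic groups seen at this place cannot be told apart. Acetamido in place of fluoro on an aromatic carbon gives (a 1.6-fold lower number from compound 2 to compound 4 (0.22 log units; within the scatter)), and nothing measured here offers a reason for any of these steps.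

As far as these compounds go, whether a group without an aromatic ring, such as cyclohexyl or methyl, would give a number beyond the scatter at the chain carbon remains open. The same question stands for an amine or a carboxylic acid in place of acetamido.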